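The source may hold more compounds than are shown below. What is called first, only, known or untested is meant among the compounds shown, and "the series" means these compounds.

Compound 1 `COc1cccc(-c2c(C)n(Cc3c(F)cccc3F)c(=O)n(C[C@@H](N)CC(C)C)c2=O)c1F` gives 39 nM in an assay on HEK293 cells for binding affinity to Gonadotropin-releasing hormone receptor (Homo sapiens), read by radioligand binding; a higher number here means a weaker inhibitor, a lower number a stronger inhibitor.
Compound 2 `COc1cccc(-c2c(C)n(Cc3c(F)cccc3F)c(=O)n(C[C@@H](N)CCc3ccccc3)c2=O)c1F` gives 965 nM in this assay.
Compound 3 `COc1cccc(-c2c(C)n(Cc3c(F)cccc3F)c(=O)n(C[C@@H](N)C3CCCC3)c2=O)c1F` gives 94 nM in this assay.

Compound 3 stands second highest of the three numbers: compound 1 is nearest, with a 2.4-fold higher number from compound 1 to compound 3 (0.38 log units; beyond the scatter), and compound 2 furthest, with a 10-fold lower number from compound 2 to compound 3 (1.01 log units; beyond the scatter). For the measured compounds named here, compound 4 `COc1cccc(-c2c(C)n(Cc3c(F)cccc3F)c(=O)n(C[C@H](N)C3CCCC3)c2=O)c1F` has not been measured. the two compounds have the same atoms and bonds and differ only in configuration as drawn: 1 of 1 stereo elements differ; a stereocentre at a saturated chain carbon is drawn S in compound 3 and R in compound 4 No measured step bears on a change of configuration: the steps of a 25-fold higher number from compound 1 to compound 2 (1.39 log units; beyond the scatter) and a 2.4-fold higher number from compound 1 to compound 3 (0.38 log units; beyond the scatter) exchange groups at the chain carbon and leave the drawn configuration untouched. The direction in this assay therefore cannot be read from the measured compounds. The estimate for compound 4 is 400 nM, between 60 nM and 3000 nM. This expectation means a 4.3-fold higher number from compound 3 to compound 4 (0.63 log units; beyond the scatter), a weakening held with low confidence.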

Compound 4, inhibition constant: 10 nM
Compound 4: the middle estimate sits 40-fold (1.60 log units) above what was measured; the measured number lies below the stated range.
By their numbers in this assay, from the lowest: compound 4; then compound 1; then compound 3; then compound 2.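

At the chain carbon carrying the amine, configuration alone moves the number in this assay, with a 9.4-fold lower number from compound 3 to compound 4 (0.97 log units; beyond the scatter), and this step can be laid on the stereocentre because of one fact: the fact that compounds 3 and 4 differ only in the configuration as drawn. The other two steps, a 3.9-fold lower number from compound 1 to compound 4 (0.59 log units; beyond the scatter) and a 97-fold lower number from compound 2 to compound 4 (1.98 log units; beyond the scatter), exchange the group and change the drawn configuration together, so they do not separate the two effects.

Going by these compounds, whether the isobutyl and phenethyl chains respond to inversion in the same direction stays open. So does whether the R drawing remains favoured with a methyl group on that carbon, or with a hydroxyl group in place of the amine.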